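The compounds below may be only part of what the source reports. "The series", "measured", "known", "first", "only" and "open" are said of these compounds alone.

Measured compounds:
Compound 1, `CC(O)(CSc1cccc(C(F)(F)F)c1)C(=O)Nc1ccc(S(F)(F)(F)(F)F)cc1`: 26200 nM
Compound 2, `CC(O)(CSc1cc(C(F)(F)F)cc(C(F)(F)F)c1)C(=O)Nc1ccc(S(F)(F)(F)(F)F)cc1`: 29700 nM
Compound 3, `CC(O)(COc1cccc(C(F)(F)F)c1)C(=O)Nc1ccc(S(F)(F)(F)(F)F)cc1`: 21900 nM

In a functional assay on DU-145 cells (Homo sapiens) for antiproliferative activity, read by propidium iodide staining, with a stated time of 96 h (on this read-out higher numbers stand for weaker inhibition and lower numbers for stronger inhibition), compound 1 gives 26200 nM and compound 2 gives 29700 nM. The two differ by one change, (trifluoromethyl in place of hydrogen on an aromatic carbon), and the step is a 1.1-fold higher number from compound 1 to compound 2 (0.05 log units; within the scatter). Compound 3 gives 21900 nM in this assay; its values and those of compound 1 and compound 2 all lie within the scatter of one another, so no ordering among the three can be read from them.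

Compound 4, `CC(O)(COc1cc(C(F)(F)F)cc(C(F)(F)F)c1)C(=O)Nc1ccc(S(F)(F)(F)(F)F)cc1`, has not yet been measured. It stands to compound 3 as compound 2 stands to compound 1: the change is trifluoromethyl in place of hydrogen on an aromatic carbon, the same change made from compound 1 to compound 2. The difference between the core of compound 3 and the core of compound 1 is not broken down here.

Given that the same change from compound 1 to compound 2 gave a 1.1-fold higher number from compound 1 to compound 2 (0.05 log units; within the scatter), the step from compound 3 to compound 4 is expected to be small as well, about a 1.1-fold higher number from compound 3 to compound 4 (0.06 log units; within the scatter) in this assay. Compound 4 is therefore estimated at 25000 nM, with a likely range from 13000 nM to 48000 nM.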

Compound 4, half-maximal inhibitory concentration: 8600 nM
Compound 4: middle estimate off by 2.9-fold (0.46 log units), on the high side; the measured number lies below the stated range.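

In this assay, trifluoromethyl in place of hydrogen on an aromatic carbon gave a 2.5-fold lower number from compound 3 to compound 4 (0.41 log units; beyond the scatter) while the same change gave a 1.1-fold higher number from compound 1 to compound 2 (0.05 log units; within the scatter). The change therefore did not carry over unaltered from one core to the other, and the two steps differ: the same change on two cores in this assay, a 1.1-fold higher number (0.05 log units; within the scatter) from compound 1 to compound 2 and a 2.5-fold lower number (0.41 log units; beyond the scatter) from compound 3 to compound 4, 2.9-fold (0.46 log units) apart, beyond the scatter of two such steps. This rests on a single pair of steps, so it shows only that the result of this change depended on the core in these four compounds; it does not show which feature of the two cores is responsible, nor how the change would behave on any further core.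

From the compounds shown here alone, whether a nitrile or a chlorine atom in place of the added trifluoromethyl would give a step of similar size on the core of compound 3 remains open. So does the effect of an amine in place of the hydroxyl group on either core.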